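Methoxy Substitution on a Styryl Lactam Series

This account rests on a few compounds, and the source may have more. Where it says the series, first, only, none or still open, it means among the compounds named here.

compound 1, `O=C1C=CCC(/C=C/c2ccccc2)N1`, 607 uM
compound 2, `COc1ccc(/C=C/C2CC=CC(=O)N2)cc1`, > 1090 uM
compound 3, `COc1cc(/C=C/C2CC=CC(=O)N2)cc(OC)c1`, 146 uM

In a functional assay on MCF7 cells (Homo sapiens) for inhibition, read by sulforhodamine B assay, with a stated time of 48 h (a higher number here means a weaker inhibitor of growth, a lower number a stronger inhibitor of growth), compound 1 gives 607 uM. For compound 2 the value > 1090 uM is a limit of the assay and not a number, (the limit of > 1090 uM in this assay, at which 1 of the 3 values shown sits). Compound 3 gives 146 uM, the lowest of the two numbers shown, and it stands a clear step from compound 1. The difference between the cores of compound 1 and compound 3 is not broken down here. The change methoxy in place of hydrogen on an aromatic carbon produced an at least 1.7-fold higher number from compound 1 to compound 2 (0.25 log units; that floor lies within the scatter). Compound 4 `COc1cc(/C=C/C2CC=CC(=O)N2)cc(OC)c1OC` has not yet been measured; it arises from compound 3 by methoxy in place of hydrogen on an aromatic carbon, the same kind of change, though here the entering group sits ortho to two methoxy groups (2 heavy atoms each) as well as para to a group of 9 heavy atoms. Resting on an at least 1.7-fold higher number from compound 1 to compound 2 (0.25 log units; that floor lies within the scatter), compound 4 is expected to show a 1.7-fold higher number from compound 3 to compound 4 (0.23 log units; within the scatter). The estimate for compound 4 is 250 uM, within 80 uM to 800 uM.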

Compound 4, concentration for growth inhibition (reported as GI): > 864 uM
Compound 4: a limit, no number; the forecaster's own chance of this, stated with the estimate: 25%; at least 3.4-fold (0.53 log units) between middle value and limit.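

In this assay compound 4 gives > 864 uM, which is a limit of the assay and not a number. Methoxy in place of hydrogen on an aromatic carbon, here ortho to two methoxy groups and para to a group of 9 heavy atoms, gives an at least 5.9-fold higher number from compound 3 to compound 4 (0.77 log units; beyond the scatter), so on the core of compound 3 the change yields a weaker inhibitor of growth. Both steps with this change are floors and not sizes, so the series shows neither a fixed size for the change nor a difference between the two cores: the same change on two cores in this assay, an at least 1.7-fold higher number (0.25 log units; that floor lies within the scatter) from compound 1 to compound 2 and an at least 5.9-fold higher number (0.77 log units; beyond the scatter) from compound 3 to compound 4; the limit leaves it open whether they differ.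

The compounds shown leave open what other groups would do on the same aromatic carbon, such as a hydroxyl, a fluorine or an amine, and whether any of them would hold the number of compound 3, 146 uM. They also leave open whether a longer chain in place of a methoxy group would read differently in this assay.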